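Working notes: adding fluoro to compound 2

This account rests on a few compounds, and the source may have more. Where it says the series, first, only, none or still open, it means among the compounds named here.

Measured so far in an ADME assay on THP-1 cells (Homo sapiens) for cytotoxicity, read by flow cytometry and propidium iodide staining, with a stated time of 72 h (on this read-out lower numbers stand for stronger inhibition and higher numbers for weaker inhibition), the compounds stand as follows:
- compound 1 `Nc1ccc2oc(-c3ccccc3F)cc(=O)c2c1` gives 44000 nM
- compound 2 `Nc1ccc2oc(-c3ccccc3)c(O)c(=O)c2c1` gives 27000 nM

Compound 2 and compound 1 lie within the usual scatter of each other, so neither stands apart. Compound 3 `Nc1ccc2oc(-c3ccccc3F)c(O)c(=O)c2c1` has fluoro in place of hydrogen on an aromatic carbon of compound 2 (fluoro in place of hydrogen on an aromatic carbon). Among the compounds with values here, no measured pair shows this change in this assay on its own, so no step beyond the scatter is expected, in either direction. The expected change is slight (a 1.1-fold higher number from compound 2 to compound 3 (0.05 log units; within the scatter)). Compound 3 is estimated at 30000 nM (expected range 14000 nM to 60000 nM).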

Compound 3, half-maximal inhibitory concentration: 38000 nM
The estimate for compound 3 lay 1.3-fold (0.10 log units) below the measured number, and the stated range covers the measured number.
By their numbers in this assay, from the lowest: compounds 2, 3 and 1 (each within the scatter of the next).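

In this assay, fluoro in place of hydrogen on an aromatic carbon, ortho to a large group, now has a reading of its own (a 1.4-fold higher number from compound 2 to compound 3 (0.15 log units; within the scatter)). The added hydroxy group also has one (a 1.2-fold lower number from compound 1 to compound 3 (0.06 log units; within the scatter)), so on this core neither change moves the number beyond the scatter. Nothing measured offers a reason for either step.

Open, going by these compounds, is whether a chloro or methoxy group at this place would give a step beyond the scatter. Also open, on these data alone, is whether an amine in place of the hydroxy would do so.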